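The source may hold more compounds than are shown below. What is called first, only, known or untested is meant among the compounds shown, and "the series" means these compounds.

Measured compounds in the series:

- compound 1, `Cc1n[nH]c(C)c1-c1cc2c(s1)C(=O)NC(C)(C)N2C`: 2100 nM
- compound 2, `CCc1n[nH]cc1-c1cc2c(s1)C(=O)NC(C)(C)N2C`: 350 nM
- compound 3, `CC1(C)NC(=O)c2sc(-c3ccncc3)cc2N1`: 90 nM

In an assay for inhibition of Rho-associated protein kinase 1 (Homo sapiens), read by TR-FRET, with stated times of 5 min and 2 h (a lower number here means a stronger inhibitor, a higher number a weaker inhibitor), compound 3 gives 90 nM, the lowest of the three numbers. The nearest is compound 2, whose number is higher by a margin beyond the scatter of repeated measurements, and the furthest is compound 1, whose number is higher still, again well beyond the scatter. Going by the values given here, each of these three carries a different aryl group on the shared core, and no two of them differ in only one place, so no single step between measured compounds is available.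

Compound 4, `CCC1(C)NC(=O)c2sc(-c3ccncc3)cc2N1`, is the next compound to be measured. It differs from compound 3 by methyl in place of hydrogen on a saturated chain carbon bound to a saturated ring carbon. Among the compounds with values here, nothing among the measured compounds shows what this change does in this assay; the aryl group and the rest of the core are the same as in compound 3. Within the data shown here, with no comparable step in hand, the expectation is a small step, in either direction, most likely not beyond the scatter. Compound 4 is therefore expected to give about 110 nM, within a range of 40 nM to 300 nM. This expectation corresponds to an estimated step of a 1.2-fold higher number from compound 3 to compound 4 (0.09 log units; within the scatter).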

Compound 4, half-maximal inhibitory concentration: 36 nM
Compound 4: middle estimate off by 3.1-fold (0.49 log units), on the high side; measured number outside the range, below it.
By their numbers in this assay, from the lowest: compound 4; then compound 3; then compound 2; then compound 1.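

Within this assay methyl in place of hydrogen on a saturated chain carbon bound to a saturated ring carbon gives the first single-place step in the series (a 2.5-fold lower number from compound 3 to compound 4 (0.40 log units; beyond the scatter)), a modest change but one beyond the scatter. This place on the shared core therefore responds to substitution, and read one bond further out, the change from methyl to ethyl goes with the lower number while the aryl group and the rest of the core stay the same. Nothing measured here accounts for this step, so it stands as an observation without an explanation.

Going by these compounds, one step gives a direction for ethyl alone, and it remains open whether a longer chain such as propyl, a branched group such as isopropyl, or a small ring such as cyclopropyl at this place would extend the trend, stop it or reverse it. Also open, on these data alone, is whether the same change would give a similar step on the different aryl groups and core of compound 1 and compound 2, since no single-place comparison links either of them to this pair.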